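The compounds below may be only part of what the source reports. "The series", "measured", "known", "first", "only" and "open" are said of these compounds alone.

Measured compounds:
Compound 1 `Cc1ccc(NC(=S)NC(=O)c2ccc(OCc3cccc(F)c3)cc2)cc1-c1nc2ccccc2[nH]1` gives > 100000 nM in a functional assay on SW-620 cells (Homo sapiens) for inhibition, read by MTT assay, with a stated time of 48 h; on this read-out higher numbers stand for weaker inhibition and lower numbers for stronger inhibition; this is a limit of the assay, not a number (the limit of > 100000 nM in this assay, at which 1 of the 3 values shown sits).
Compound 2 `Cc1ccc(NC(=S)NC(=O)c2ccc(OCc3ccc(Cl)cc3Cl)cc2)cc1-c1nc2ccccc2[nH]1` gives 57200 nM in this assay.
Compound 3 `Cc1ccc(NC(=O)NC(=O)c2ccc(OCc3ccc(C(F)(F)F)cc3)cc2)cc1-c1nc2ccccc2[nH]1` gives 15300 nM in this assay.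

Within the data shown here, of the two numbers reported, compound 3 holds the lowest; its nearest neighbour, compound 2, stands higher by a gap beyond the scatter, but compound 2 and compound 3 differ from each other in more than one place, so no single step connects them.

Compound 4 `Cc1ccc(NC(=O)NC(=O)c2ccc(OCc3ccc(Cl)cc3Cl)cc2)cc1-c1nc2ccccc2[nH]1` is not yet measured. It differs from compound 3 by 2,4-dichlorophenyl in place of 4-(trifluoromethyl)phenyl on a saturated chain carbon bound to an oxygen on an aromatic ring. Among the measured compounds shown here, the only measured step at the same position is an at least 1.7-fold lower number from compound 1 to compound 2 (0.24 log units; that floor lies within the scatter), taken within compounds 1 and 2; because compound 1 sits at the limit (the limit of > 100000 nM in this assay, at which 1 of the 3 values shown sits), only a floor for that step is known, and the floor lies within the scatter. For the measured compounds named here, no measured step exists among compounds sharing the rest of compound 3, so the transfer of the 2,4-dichlorophenyl change onto compound 3 rests on that one floor only.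

Given that, the expected step from compound 3 to compound 4 in this assay is a 1.2-fold higher number from compound 3 to compound 4 (0.07 log units; within the scatter), with no direction that would clearly exceed the scatter. Compound 4 is therefore estimated at 18000 nM, with a range from 6000 nM to 60000 nM.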

Compound 4, half-maximal inhibitory concentration: 12200 nM
Compound 4: the middle estimate sits 1.5-fold (0.17 log units) above what was measured, and the stated range covers the measured number.
By their numbers in this assay, from the lowest: compounds 4 and 3 (each within the scatter of the next); then compound 2. At a limit, above all of these: compound 1.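

In this assay, on a saturated chain carbon bound to an oxygen on an aromatic ring, 2,4-dichlorophenyl in place of 4-(trifluoromethyl)phenyl gives a 1.3-fold lower number from compound 3 to compound 4 (0.10 log units; within the scatter), so this read-out does not separate the two groups at this position. Among these compounds, this is the first step at this position with a number at both ends, whereas the earlier one, an at least 1.7-fold lower number from compound 1 to compound 2 (0.24 log units; that floor lies within the scatter), offers only a floor. That earlier step stays a floor because compound 1, at > 100000 nM, stands at a limit of the assay and not at a number: the limit of > 100000 nM in this assay, at which 1 of the 4 values shown sits.

From the compounds shown here alone, with the same 2,4-dichlorophenyl group, compound 2, which carries a thiocarbonyl, gives 57200 nM and compound 4, which carries a carbonyl there, gives 12200 nM, but what that one exchange does across the series remains open, as this single pair is all there is to go on. Also open, going by these compounds, is whether an amine or a carboxylic acid in place of the 2,4-dichlorophenyl, or a longer chain in place of the benzyl, would move the number beyond the scatter.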